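From a Fluorinated Aryl to an Iodinated One

A few compounds are considered here, and "the series" means these few. Any claim that something is new, unique, unknown or untested is made for them only; others in the source may bear on it.

Compound 1 `Nc1scc(-c2cccc(F)c2)c1C(=O)c1ccccc1` is the lower of the two compounds measured in a functional assay on CHO cells for agonist activity at adenosine receptor A1 (Homo sapiens), read by fluorescence and ERK phosphorylation, with stated times of 30 min and 1.5 h, tested at 3 uM (on this read-out higher numbers stand for a stronger effect at the one concentration tested and lower numbers for a weaker effect), where compound 1 gives 51%. Among the compounds with values here, its only measured neighbour, compound 2 `Nc1scc(-c2cccc(Br)c2)c1C(=O)c1ccccc1`, gives 67% in this assay, and the step of a number 16 percentage points higher from compound 1 to compound 2 (beyond the scatter) lies beyond the scatter. Compound 3 `Nc1scc(-c2ccc(I)cc2)c1C(=O)c1ccccc1` has not yet been measured. It differs from compound 1 in one place: 4-iodophenyl in place of 3-fluorophenyl on an aromatic carbon. Within the data shown here, the one step that bears on this change is the one from compound 1 to compound 2, where exchanging one halogen for another on the same aryl group raised the read-out by a modest amount. Among the measured compounds shown here, compound 3 changes both the halogen and where it sits on the ring, and no measured step tests that second part. A rise of similar size is therefore expected, a number 14 percentage points higher from compound 1 to compound 3 (beyond the scatter). Compound 3 is estimated at 65% in this assay, within a range from 42% to 85%.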

Compound 3, a percentage reported as activity, at one concentration (the size of the read-out at that concentration, not a potency): 51%
Beside the measured number, compound 3's estimate is 14 percentage points above it; the range from low to high includes it.
By their numbers in this assay, from the lowest: compounds 1 and 3 (each within the scatter of the next); then compound 2.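

In this assay, the change to 4-iodophenyl gives no change at the digits printed from compound 1 to compound 3 (within the scatter), so at this position on the shared core, exchanging the halogen does not always raise the read-out as it did with the bromo group. Set against the 3-bromophenyl group, the same 4-iodophenyl group gives a number 16 percentage points lower from compound 2 to compound 3 (beyond the scatter), which leaves compound 2 as the only one of the three that stands clear of the others. Nothing available here explains this difference.

The compounds shown leave open whether the identity of the halogen or its place on the phenyl ring accounts for the drop, as compound 3 changes both at once. Also open, going by these compounds, is how a phenyl ring carrying a methoxy group or a carboxylic acid instead of a halogen would read in this assay.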